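The source may report more compounds than this note shows. Statements on the series, on what has been measured and on what is new or still open speak of the compounds shown alone.

Measured so far:
compound 1, `COc1ccc(CN(C(=O)CCl)c2cc(OC)c(OC)c(OC)c2)cc1O` — 84 nM
compound 2, `C/C=C/C(=O)N(Cc1ccc(OC)c(Br)c1)c1cc(OC)c(OC)c(OC)c1` — 6430 nM
compound 3, `COc1ccc(CN(C(C)=O)c2cc(OC)c(OC)c(OC)c2)cc1O` — 79 nM

In a functional assay on MGC-803 cells (Homo sapiens) for inhibition, read by MTT assay, with a stated time of 48 h (a lower number here means a stronger inhibitor, a higher number a weaker inhibitor), compound 3 gives the lowest number of the three, but compound 1 stands within the scatter of it; the separation from compound 2 is the only one beyond the scatter, and compound 2 differs from compound 3 in more than one place, so no single step accounts for it. Among the measured compounds shown here, the one step recorded in this set, a 1.1-fold lower number from compound 1 to compound 3 (0.03 log units; within the scatter), is within the scatter; it sits on the same saturated chain carbon bound to the carbonyl carbon that is varied next.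

Compound 4, `COCC(=O)N(Cc1ccc(OC)c(O)c1)c1cc(OC)c(OC)c(OC)c1`, differs from compound 3 by methoxy in place of hydrogen on a saturated chain carbon bound to a carbonyl carbon.

Bearing on this is only the step from compound 1 to compound 3, which was small and in the same place. A small step is therefore expected for compound 4 as well, with no direction that the data can support beyond the scatter; the estimate for compound 4 is 100 nM, within 40 nM to 300 nM, which amounts to an expected step of a 1.3-fold higher number from compound 3 to compound 4 (0.10 log units; within the scatter). For the measured compounds named here, the range is kept wide because a substituent of this kind has not yet been measured at this place, and the estimate rests on the one step within the scatter.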

Compound 4, half-maximal inhibitory concentration: 79 nM
Compound 4: the middle estimate sits 1.3-fold (0.10 log units) above what was measured; low and high end bracket the measured number.
By their numbers in this assay, from the lowest: compounds 3, 4 and 1 (each within the scatter of the next); then compound 2.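

In this assay, methoxy in place of hydrogen on the saturated chain carbon bound to a carbonyl carbon gives no change at the digits printed from compound 3 to compound 4 (within the scatter), and methoxy in place of chloro gives a 1.1-fold lower number from compound 1 to compound 4 (0.03 log units; within the scatter). The earlier compounds shown here compared only chloro and hydrogen at this place; the series now adds a group of 2 heavy atoms with 1 hydrogen-bond acceptor, and none of the steps among hydrogen, chloro and methoxy goes beyond the scatter, so the chloro of compound 1 is not needed for a number of this size. Nothing measured here gives a reason for this flat reading, which holds only for compounds 1, 3 and 4.

Still open, from the compounds shown here alone, is whether the reading stays flat with a longer chain, an amine or a carboxylic acid on this saturated chain carbon. Compound 2, at 6430 nM, differs from these three in more than one place, so its number cannot be assigned to any single change and says nothing specific about this position.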